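The source may hold more compounds than are shown below. What is called first, only, known or untested is meant among the compounds shown, and "the series" means these compounds.

Measured compounds in a functional assay on SK-OV-3 cells (Homo sapiens) for cytotoxicity, read by MTT assay, with a stated time of 48 h; a higher number here means a weaker inhibitor, a lower number a stronger inhibitor:
compound 1 `O=C(/C=C/c1ccc2c(c1)B(O)OC2)c1ccccc1` — 3400 nM
compound 2 `O=C(/C=C/c1ccc2c(c1)B(O)OC2)c1ccc(C(F)(F)F)cc1` — 3700 nM
compound 3 `O=C(/C=C/c1ccc2c(c1)B(O)OC2)c1cccc(F)c1` — 4800 nM

The three numbers sit close together. Compound 1 is not separated from compound 2, the step being a 1.1-fold higher number from compound 1 to compound 2 (0.04 log units; within the scatter), nor from compound 3, where the step is a 1.4-fold higher number from compound 1 to compound 3 (0.15 log units; within the scatter). On these numbers compound 1 serves as the reference point of the set, with nothing beyond the scatter on either side of it.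

Compound 4 `COCOc1ccccc1C(=O)/C=C/c1ccc2c(c1)B(O)OC2` differs from compound 1 in one place: methoxymethoxy in place of hydrogen on an aromatic carbon. The two measured steps are the ones that bear on this change, since each also swaps a hydrogen on an aromatic carbon of the same six-membered aromatic ring of carbon only for another group, and both stayed within the scatter. Among the compounds with values here, no measured step involves a methoxymethoxy group or a group of comparable size, so the evidence is indirect.

On that basis the expected step of a 1.1-fold higher number from compound 1 to compound 4 (0.02 log units; within the scatter) is none beyond the scatter, in this assay. Compound 4 is therefore estimated at 3600 nM, with a range of 1800 nM to 7500 nM.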

Compound 4, half-maximal inhibitory concentration: 6500 nM
Compound 4: the middle estimate sits 1.8-fold (0.26 log units) below what was measured, and the stated range covers the measured number.
By their numbers in this assay, from the lowest: compounds 1, 2, 3 and 4 (each within the scatter of the next).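

In this assay, methoxymethoxy in place of hydrogen on an aromatic carbon, ortho to a large group, gives a 1.9-fold higher number from compound 1 to compound 4 (0.28 log units; within the scatter) and so does not separate the two compounds. Within the data shown here, this place therefore accepts a chain of 4 heavy atoms with 2 hydrogen-bond acceptors and no step beyond the scatter, something the earlier compounds could not show, as none of them carries a group ortho to a large group. Nothing available bears on what underlies this result.

Open, as far as these compounds go, is whether a hydroxy group, an amine or a carboxylic acid at this same place would also stay within the scatter in this assay as well. Equally open, from the compounds shown here alone, is whether a longer chain, such as butoxy, would hold to that pattern.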